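Dropping an Amino Group from a Weak Growth Inhibitor

The source may hold more compounds than are shown below. What is called first, only, known or untested is meant among the compounds shown, and "the series" means these compounds.

Of the compounds shown here, two built on one shared core have been measured in a functional assay on M14 cells (Homo sapiens) for cytotoxicity, read by sulforhodamine B assay, with a stated time of 48 h; a higher number here means a weaker inhibitor of growth, a lower number a stronger inhibitor of growth. Compound 1 `Nc1nc(Cl)c2ncn(Cc3ccccc3CCl)c2n1` gives 39800 nM, the higher of the two numbers. Compound 2 `ClCc1ccccc1Cn1cnc2nc(Cl)nc(Cl)c21` gives 3460 nM, a gap that lies beyond the usual scatter, so compound 2 is the stronger inhibitor of the pair. Compound 3 `ClCc1ccccc1Cn1cnc2c(Cl)ncnc21` has not yet been measured. It differs from compound 1 in one place only: hydrogen in place of amino on an aromatic carbon. The change sits between two ring nitrogen atoms of the core. Since compound 2 already shows a lower number than compound 1 once the amino group is gone, the step of a 3.3-fold lower number from compound 1 to compound 3 (0.52 log units; beyond the scatter) is expected to point toward a lower number, though the size of this expected step is uncertain. The estimate for compound 3 in this assay is 12000 nM, with a likely range from 3500 nM to 40000 nM.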

Compound 3, concentration for total growth inhibition: 3710 nM
Estimate against measurement, compound 3: 3.2-fold (0.51 log units) above; measured number inside the range.
By their numbers in this assay, from the lowest: compounds 2 and 3 (each within the scatter of the next); then compound 1.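

Within the data shown here, until now, no two compounds differed in one place, so the effect of the amino group could not be read on its own. In this assay, hydrogen in place of amino gives an 11-fold lower number from compound 1 to compound 3 (1.03 log units; beyond the scatter) and this large step is beyond the scatter. It shows that this single change, on an aromatic carbon between two ring nitrogen atoms, is enough to turn compound 1 into a clearly stronger inhibitor of growth, so the amino group is not needed there for this activity.

Still open, from the compounds shown here alone, is whether a methyl group or a hydroxyl group on the same carbon would give a number closer to that of hydrogen or to that of amino. No measurement at hand explains why this change has so large an effect.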